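Working notes: nitro to diethylamino on a six-membered ring

The source may hold more compounds than are shown below. What is called first, only, known or untested is meant among the compounds shown, and "the series" means these compounds.

Measured in an assay on isolated protein for binding affinity to corticotropin-releasing factor receptor 1 (Homo sapiens); on this read-out lower numbers stand for stronger inhibition and higher numbers for weaker inhibition:
Compound 1 `CCCN(Cc1ccccc1)c1cc(C)nc2c(-c3ncc(C(F)(F)F)cc3Cl)c(C)nn12`: 1.7 nM
Compound 2 `CCCN(CCC)c1cc(C)nc2c(-c3ncc([N+](=O)[O-])cc3C)c(C)nn12`: 9.1 nM
Compound 3 `CCCN(CCC)c1cc(C)nc2c(-c3ncc(C)cc3[N+](=O)[O-])c(C)nn12`: 14 nM

Compound 2 stands second highest of the three numbers. Compound 3 lies within the scatter of it, so no order between the two can be read. Compound 1 gives a lower number, beyond the scatter.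

Compound 4 `CCCN(CCC)c1cc(C)nc2c(-c3ncc(N(CC)CC)cc3C)c(C)nn12` differs from compound 2 by diethylamino in place of nitro on an aromatic carbon. Going by the values given here, no measured pair isolates this change, so its size is unknown from the series itself. The expectation is a step from compound 2 to compound 4 of a 2.7-fold higher number from compound 2 to compound 4 (0.44 log units; beyond the scatter) in this assay, toward a higher number, with wide uncertainty. Compound 4 is therefore estimated at 25 nM, with a range from 6 nM to 100 nM.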

Compound 4, inhibition constant: 13 nM
The estimate for compound 4 lay 1.9-fold (0.28 log units) above the measured number, and the stated range covers the measured number.
By their numbers in this assay, from the lowest: compound 1; then compounds 2, 4 and 3 (each within the scatter of the next).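

In this assay, diethylamino in place of nitro on this aromatic carbon, para to a large group, gives a 1.4-fold higher number from compound 2 to compound 4 (0.15 log units; within the scatter) and so leaves the read-out within the scatter. The earlier compounds shown here held no pair isolating any change at this position. Here a group with more heavy atoms and one hydrogen-bond acceptor fewer is read as no different from nitro, and no evidence at hand accounts for this.

As far as these compounds go, whether a primary amine or a carboxylic acid on this carbon would also stay within the scatter remains open. So does whether a longer chain on the amine would.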